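Notes on compound 4 from compound 3

This account rests on a few compounds, and the source may have more. Where it says the series, first, only, none or still open, it means among the compounds named here.

Among the compounds with values here, compound 3 `O=C1CCCN1c1cnc(NCc2c(F)ccc3c2CCO3)n2cnnc12` gives 1.3 in a physicochemical assay for lipophilicity, using the shake flask method, in phosphate buffer, measured as octanol-water partition, with a stated time of 30 min, at pH 7.4 (a lower number here means a more polar compound, a higher number a more lipophilic compound), the lowest of the three numbers measured so far; compound 2 `Cn1cc(-c2cnc(NCc3c(F)ccc4c3CCO4)c3cn[nH]c(=O)c23)cn1` gives 2.7 and compound 1 `Cc1cc(-c2cnc(NCc3c(F)ccc4c3CCO4)c3cn[nH]c(=O)c23)n(C)n1` gives 3, each beyond the scatter above compound 3. Compound 4 `CN(c1ccn(C)n1)c1cnc(NCc2c(F)ccc3c2CCO3)n2cnnc12` differs from compound 3 in one place: methyl(1-methyl-1H-pyrazol-3-yl)amino in place of 2-oxopyrrolidin-1-yl on an aromatic carbon. Within the data shown here, the single measured step, a number 0.30 log units lower from compound 1 to compound 2 (within the scatter), exchanges one pyrazolyl group for another on a different core and says little about replacing 2-oxopyrrolidin-1-yl with a pyrazolyl group. Among the measured compounds shown here, the higher numbers of compounds 1 and 2, both carrying a pyrazolyl group, are the only guide. An upward step of a number 1.20 log units higher from compound 3 to compound 4 (beyond the scatter) is therefore expected for compound 4. Compound 4 is estimated at 2.5, within a range of 1.9 to 3.1.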

Compound 4, distribution coefficient: 1.8
Beside the measured number, compound 4's estimate is 0.70 log units above it; the whole stated range lies above it.
By their numbers in this assay, from the lowest: compound 3; then compound 4; then compounds 2 and 1 (each within the scatter of the next).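

In this assay, methyl(1-methyl-1H-pyrazol-3-yl)amino in place of 2-oxopyrrolidin-1-yl on an aromatic carbon gives a number 0.50 log units higher from compound 3 to compound 4 (beyond the scatter), a modest step. It is the only reading of a change at this position on this core, and it shows that the number here responds to the exchange, whereas the other step shown, between two pyrazolyl groups on a different core, stays within the scatter.

As far as these compounds go, whether a dimethylamino group or a carboxylic acid at this position would give a larger step remains open, as does the size of this same exchange on another core. Nothing shown accounts for the size of the step.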